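A few compounds are considered here, and "the series" means these few. Any claim that something is new, unique, unknown or untested is made for them only; others in the source may bear on it.

Measured compounds in this series:

- compound 1 `O=C(/C=C/c1ccc(O)c(O)c1)N1CCCN(S(=O)(=O)c2cccc3cnccc23)CC1` gives 2130 nM
- compound 2 `O=C(CCc1ccc(O)c(O)c1)N1CCCN(S(=O)(=O)c2cccc3cnccc23)CC1` gives 730 nM

Both numbers come from an assay on isolated protein for inhibition of Rho-associated protein kinase 2 (Homo sapiens), read by 33P incorporation, with a stated time of 30 min, in the presence of a further agent that is not named here; a lower number here means a stronger inhibitor, a higher number a weaker inhibitor. For the measured compounds named here, compound 2 stands at the lower of the two numbers, and the single measured step, a 2.9-fold lower number from compound 1 to compound 2 (0.47 log units; beyond the scatter), lies beyond the scatter.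

Compound 3 `COc1cc(/C=C/C(=O)N2CCCN(S(=O)(=O)c3cccc4cnccc34)CC2)ccc1O` differs from compound 2 by 2-(4-hydroxy-3-methoxyphenyl)ethenyl in place of 2-(3,4-dihydroxyphenyl)ethyl on a carbonyl carbon. The change has two parts. The saturated two-carbon link of compound 2 becomes the ethenyl link of compound 1, and one of the two hydroxyl groups becomes a methoxy group. Only the first part has a measured counterpart: the step from compound 1 to compound 2 run in the reverse direction, a modest shift to a higher number. Going by the values given here, the exchange of hydroxyl for methoxy has no counterpart among the measured compounds, so its direction and size remain open.

On this basis compound 3 is expected to give a higher number than compound 2, of about the size of the measured step, an expected step of a 2.7-fold higher number from compound 2 to compound 3 (0.44 log units; beyond the scatter). The estimate for compound 3 in this assay is 2000 nM, with a range from 700 nM to 6000 nM.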

Compound 3, half-maximal inhibitory concentration: 2610 nM
The estimate for compound 3 lay 1.3-fold (0.12 log units) below the measured number; measured number inside the range.
By their numbers in this assay, from the lowest: compound 2; then compounds 1 and 3 (each within the scatter of the next).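

In this assay, the hydroxyl-to-methoxy exchange now has its own reading, methyl in place of hydrogen on an oxygen on an aromatic ring (a 1.2-fold higher number from compound 1 to compound 3 (0.09 log units; within the scatter)), so at this position the exchange does not separate compound 3 from compound 1. The other new reading (a 3.6-fold higher number from compound 2 to compound 3 (0.55 log units; beyond the scatter)) places compound 2 on its own with the 2-(3,4-dihydroxyphenyl)ethyl group, while both compounds with an ethenyl link, compound 1 and compound 3, carry the higher numbers. No supporting data accompany these numbers to explain them.

On these data alone, the methoxy exchange has been read only on the ethenyl link, so its size on the saturated link of compound 2 remains open, as does the result of a second methoxy group in place of the remaining hydroxyl group. Also open, as far as these compounds go, is how a longer chain on the carbonyl carbon, or an amine or a carboxylic acid in place of the hydroxyl group on the aromatic ring, would read in this assay against these three compounds.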